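A few compounds are considered here, and "the series" means these few. Any claim that something is new, unique, unknown or untested is made for them only; others in the source may bear on it.

Compound 1 `CCCCn1cnc2c(Nc3ccc(Cl)cc3)nc(N[C@H]3CC[C@H](N)CC3)nc21` gives 2100 nM in a functional assay on MCF7 cells (Homo sapiens) for inhibition, read by fluorescence, with a stated time of 72 h; a lower number here means a stronger inhibitor of growth, a higher number a weaker inhibitor of growth; compound 2 `CCCCn1cnc2c(Nc3cccc(Cl)c3)nc(N[C@H]3CC[C@H](N)CC3)nc21` gives 2000 nM in this assay.

Compound 2 carries the lowest of the two numbers, yet the step of a 1.1-fold lower number from compound 1 to compound 2 (0.02 log units; within the scatter) lies within the scatter, so no order between the two is claimed. Compound 3 `COc1ccc(Cn2cnc3c(Nc4cccc(Cl)c4)nc(N[C@H]4CC[C@H](N)CC4)nc32)cc1` differs from compound 2 by 4-methoxyphenyl in place of propyl on a saturated chain carbon bound to an aromatic nitrogen. Going by the values given here, the only measured step changes the group on a nitrogen on an aromatic ring, not the saturated chain carbon bound to an aromatic nitrogen, so it does not bear on this change. With nothing to go on, compound 3 is expected near compound 2, estimated at 3000 nM (range 700 nM to 13000 nM). The expected step is a 1.5-fold higher number from compound 2 to compound 3 (0.18 log units; within the scatter).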

Compound 3, concentration for 50% growth inhibition: 4800 nM
Estimate against measurement, compound 3: 1.6-fold (0.20 log units) below; the range from low to high includes it.
By their numbers in this assay, from the lowest: compounds 2 and 1 (each within the scatter of the next); then compound 3.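

At the saturated chain carbon bound to an aromatic nitrogen, 4-methoxyphenyl in place of propyl gives a 2.4-fold higher number from compound 2 to compound 3 (0.38 log units; beyond the scatter) in this assay and so makes compound 3 a modestly weaker inhibitor of growth. Going by these compounds alone, this is the first step that lies beyond the scatter, and it shows that the number responds to a change at this place. No available evidence accounts for this step. Going by these compounds, whether the shift follows from the aromatic ring or from its methoxy group remains open. So does how a longer chain, an amine or a carboxylic acid would read at this place.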